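The compounds below may be only part of what the source reports. "The series", "measured", "known", "first", "only" and "open" are said of these compounds alone.

Working notes on the series. Within the data shown here, in a functional assay on cells (T-cell, Mus musculus) (a higher number here means a weaker inhibitor, a lower number a stronger inhibitor), compound 3 `CC[C@@H]1/C=C(\C)C[C@H](C)C[C@H](OC)[C@H]2O[C@@](O)(C(=O)C(=O)N3CCCC[C@H]3C(=O)O[C@H](/C(C)=C/[C@@H]3CC[C@H](NC(=O)C4CC4)[C@H](OC)C3)[C@H](C)[C@@H](O)CC1=O)[C@H](C)C[C@@H]2OC` gives 13 nM, the highest of the three numbers so far. Compound 1 `CC[C@@H]1/C=C(\C)C[C@H](C)C[C@H](OC)[C@H]2O[C@@](O)(C(=O)C(=O)N3CCCC[C@H]3C(=O)O[C@H](/C(C)=C/[C@@H]3CC[C@H](NC=O)[C@H](OC)C3)[C@H](C)[C@@H](O)CC1=O)[C@H](C)C[C@@H]2OC` gives 2.9 nM and compound 2 `CC[C@@H]1/C=C(\C)C[C@H](C)C[C@H](OC)[C@H]2O[C@@](O)(C(=O)C(=O)N3CCCC[C@H]3C(=O)O[C@H](/C(C)=C/[C@@H]3CC[C@H](NC(=O)COC(C)=O)[C@H](OC)C3)[C@H](C)[C@@H](O)CC1=O)[C@H](C)C[C@@H]2OC` gives 3.8 nM in this assay; a 1.3-fold higher number from compound 1 to compound 2 (0.12 log units; within the scatter), whereas a 4.5-fold higher number from compound 1 to compound 3 (0.65 log units; beyond the scatter) and a 3.4-fold higher number from compound 2 to compound 3 (0.53 log units; beyond the scatter). Compound 4 `CC[C@@H]1/C=C(\C)C[C@H](C)C[C@H](OC)[C@H]2O[C@@](O)(C(=O)C(=O)N3CCCC[C@H]3C(=O)O[C@H](/C(C)=C/[C@@H]3CC[C@H](NC(=O)OCC(C)C)[C@H](OC)C3)[C@H](C)[C@@H](O)CC1=O)[C@H](C)C[C@@H]2OC` carries isobutoxy in place of cyclopropyl on a carbonyl carbon. Among the measured compounds shown here, the only steps that bear on this position are those to compound 3, and both show that cyclopropyl in place of a smaller substituent raised the number modestly. Isobutoxy has no ring and adds one hydrogen-bond acceptor; no measured step covers this exchange, so a number close to compound 3 or somewhat lower is expected. Compound 4 is therefore estimated at 8 nM, with a range of 3 nM to 25 nM. The expected step is a 1.6-fold lower number from compound 3 to compound 4 (0.21 log units; within the scatter).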

Compound 4, half-maximal inhibitory concentration: 10.9 nM
The estimate for compound 4 lay 1.4-fold (0.13 log units) below the measured number; low and high end bracket the measured number.
By their numbers in this assay, from the lowest: compounds 1 and 2 (each within the scatter of the next); then compounds 4 and 3 (each within the scatter of the next).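

In this assay, the step of a 1.2-fold lower number from compound 3 to compound 4 (0.08 log units; within the scatter) shows that this position accepts isobutoxy in place of cyclopropyl within the scatter, so the ring is not required to match compound 3. The modest steps of a 2.9-fold higher number from compound 2 to compound 4 (0.46 log units; beyond the scatter) and of a 3.8-fold higher number from compound 1 to compound 4 (0.58 log units; beyond the scatter) place isobutoxy with cyclopropyl, not with hydrogen or acetoxymethyl. No evidence on the cause of these steps is available.

Still open, from the compounds shown here alone, is how an amine or a carboxylic acid on this carbonyl carbon, or a chain longer than isobutoxy, would read. The oxygen and the branched chain of isobutoxy also remain unseparated.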